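From 2,5-dimethylphenyl to 2,4,6-trihydroxyphenyl in compound 4

This account rests on a few compounds, and the source may have more. Where it says the series, first, only, none or still open, it means among the compounds named here.

In a functional assay on DU-145 cells (Homo sapiens) for inhibition, read by trypan blue exclusion, with a stated time of 96 h (on this read-out higher numbers stand for weaker inhibition of growth and lower numbers for stronger inhibition of growth), compound 2 (`Cc1ccc(C)c(/C=C(/Sc2ccc(Br)cc2)C(=O)c2ccc(Cl)cc2)c1`) gives 10000 nM and sits level with compound 3 (`Cc1ccc(CS/C(=C/c2cc(C)ccc2C)C(=O)c2ccc(Cl)cc2)cc1`), which gives 10000 nM on the same reading. Compound 1 (`O=C(O)c1ccc(/C=C(/SCc2ccc(Cl)cc2)C(=O)c2ccc(C(=O)O)cc2)cc1`) gives > 100000 nM in this series, and that value is a limit. Compound 4 (`O=C(/C(=C\c1c(O)cc(O)cc1O)Sc1ccc(Br)cc1)c1ccc(Cl)cc1`) has 2,4,6-trihydroxyphenyl in place of 2,5-dimethylphenyl on a double-bonded chain carbon bound to a double-bonded chain carbon. For the measured compounds named here, the only measured step, no change at the digits printed from compound 2 to compound 3 (within the scatter) here, concerns a group on a sulfur and not this place, so it bears only loosely. No shift beyond the scatter is expected, with real uncertainty in both directions. The expected outcome is no change at the digits printed from compound 2 to compound 4 (within the scatter) in this assay on present data. For compound 4 the estimate is 10000 nM with an expected range of 2500 nM to 50000 nM for now.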

Compound 4, concentration for 50% growth inhibition: 50000 nM
Compound 4: the middle estimate sits 5.0-fold (0.70 log units) below what was measured, and the stated range covers the measured number.
By their numbers in this assay, from the lowest: compounds 2 and 3 (each within the scatter of the next); then compound 4. At a limit, above all of these: compound 1.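

In this assay, for the compounds shown here, this place on a double-bonded chain carbon responds to substitution, with a 5.0-fold higher number from compound 2 to compound 4 (0.70 log units; beyond the scatter), while the only earlier step, on a sulfur, stayed within the scatter. Replacing 2,5-dimethylphenyl with 2,4,6-trihydroxyphenyl therefore weakens growth inhibition here, yet compound 4 still gives a number and not a limit: the limit of > 100000 nM in this assay, at which 1 of the 4 values shown sits.

Going by these compounds alone, the single step does not separate the loss of the methyl groups from the gain of the hydroxy groups. Going by these compounds, whether methoxy groups or an amine on this ring would read like the hydroxy groups remains open.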